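Three limits and a furan-2-yl swap

The source may report more compounds than this note shows. Statements on the series, on what has been measured and on what is new or still open speak of the compounds shown alone.

Compound 1 `Brc1ccc(Nc2nc(/C=C/c3ccccc3)nc3ccsc23)cc1` gives > 1000000 nM (a limit)
Compound 2 `COc1ccc(Nc2nc(/C=C/c3ccccc3)nc3ccsc23)cc1` gives > 1000000 nM (a limit)
Compound 3 `Fc1ccc(CNc2nc(/C=C/c3ccccc3)nc3ccsc23)cc1` gives > 1000000 nM (a limit)

These three compounds were tested in a functional assay on L02 cells (Homo sapiens) for inhibition, read by Griess assay, with stated times of 1 h and 24 h (a higher number here means a weaker inhibitor, a lower number a stronger inhibitor), and none of them gave a number. Compound 3 stands at > 1000000 nM and this is a limit of the assay. Going by the values given here, the whole picture so far is the limit of > 1000000 nM in this assay, at which 3 of the 3 values shown sit, and no compound can be ranked against another.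

The step now followed leads from compound 3 to compound 4 `Fc1ccc(CNc2nc(/C=C/c3ccco3)nc3ccsc23)cc1` and the difference is furan-2-yl in place of phenyl on a double-bonded chain carbon bound to a double-bonded chain carbon in the side chain. In words, furan-2-yl stands in place of phenyl on a double-bonded chain carbon bound to a double-bonded chain carbon.

The measured steps are a step that the two limits leave unreadable from compound 1 to compound 2 and a step that the two limits leave unreadable from compound 1 to compound 3 and a step that the two limits leave unreadable from compound 2 to compound 3 as far as they can be read. None of them has a readable size and none of them changes this place, so they give no size to carry over. No direction can be named, and no change beyond the scatter is expected. The expected outcome is a number no higher from compound 3 to compound 4 (the limit leaves the size open) and most likely another limit. For compound 4 the estimate is 1000000 nM with an expected range from 200000 nM to 2000000 nM for any number that appears.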

Compound 4, half-maximal inhibitory concentration: > 1000000 nM
Compound 4: only a limit was reported (the forecaster's own chance of this, stated with the estimate: 75%); the middle value sits exactly at the limit.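

In this assay compound 4 gives > 1000000 nM, which is a limit. Going by these compounds alone, the step between compound 3 and compound 4 therefore cannot be read, and no step among compounds 1 to 4 has a readable size. The picture remains a single limit: the limit of > 1000000 nM in this assay, at which 4 of the 4 values shown sit.

The compounds shown leave open whether any of these structures has a measurable half-maximal inhibitory concentration in this assay, and which changes would affect it.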